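The source may report more compounds than this note shows. Statements on the series, on what has been measured and on what is new or still open speak of the compounds shown alone.

Three compounds have been measured in an assay on isolated protein for inhibition of retinal dehydrogenase 2 (Homo sapiens); on this read-out higher numbers stand for weaker inhibition and lower numbers for stronger inhibition:

Compound 1, `Cn1ncc2c(=O)n(-c3ccccc3)c(SC(C)(C)c3ccccc3)nc21`, gives 2200 nM.
Compound 2, `Cn1ncc2c(=O)n(-c3ccccc3)c(CNc3cccc(F)c3)nc21`, gives 2300 nM.
Compound 3, `Cn1ncc2c(=O)n(-c3ccccc3)c(SCc3cccc(F)c3)cc21`, gives 240 nM.

Compound 2 is the starting point. Its number in this assay sits right next to that of compound 1, and the gap between the two lies within the usual scatter of repeated measurements, so nothing separates them. Compound 3 gives a clearly lower number, and that gap lies beyond the scatter; since compound 3 differs from compound 2 in more than one place, the two values only show how wide the range across this small set is.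

Compound 4, `Cn1ncc2c(=O)n(-c3ccccc3)c(COc3cccc(F)c3)nc21`, has not yet been measured. It differs from compound 2 in one place: 3-fluorophenoxy in place of (3-fluorophenyl)amino on a saturated chain carbon bound to an aromatic carbon. The two groups match in size, and the change removes one hydrogen-bond donor while keeping one acceptor. For the measured compounds named here, no measured pair in this set shows this exchange, so there is no step to lean on. The expectation for this assay is a step of modest size, if any, with its direction open. Compound 4 is therefore expected to give about 2500 nM, with a range from 800 nM to 8000 nM. This estimate implies an expected step of a 1.1-fold higher number from compound 2 to compound 4 (0.04 log units; within the scatter).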

Compound 4, half-maximal inhibitory concentration: 1770 nM
Compound 4: the middle estimate sits 1.4-fold (0.15 log units) above what was measured; the measured number falls inside the stated range.
By their numbers in this assay, from the lowest: compound 3; then compounds 4, 1 and 2 (each within the scatter of the next).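

In this assay, putting 3-fluorophenoxy in place of (3-fluorophenyl)amino on a saturated chain carbon bound to an aromatic carbon gives a 1.3-fold lower number from compound 2 to compound 4 (0.11 log units; within the scatter), so this read-out does not separate the pair. For the compounds shown here, this is the first direct exchange at this position that can be read, and for this pair it shows that the hydrogen-bond donor of the (3-fluorophenyl)amino group can be lost, with one hydrogen-bond acceptor kept, without a step beyond the scatter. Nothing available here explains this outcome or tells how the two groups behave in the assay.

As far as these compounds go, it remains open whether plain phenoxy, without the fluorine, or a longer chain ending in the same ring would stand apart from compound 2 and compound 4 by more than the scatter. Also open, from the compounds shown here alone, is which of its differences lets compound 3 reach 240 nM, since compound 3 differs from compound 2 and compound 4 in more than one place and no single change can be credited.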